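Swapping 3-nitrophenyl for 4-acetoxyphenyl

The source may hold more compounds than are shown below. What is called first, only, known or untested is meant among the compounds shown, and "the series" means these compounds.

In an ADME assay on MT4 cells (Homo sapiens) for cytotoxicity, read by MTT assay, with a stated time of 3 days (a lower number here means that less compound is tolerated, a higher number that more compound is tolerated), compound 3 `CC(C)(C)N(Cc1cccc([N+](=O)[O-])c1)C(=O)COC(=O)c1ccc([N+](=O)[O-])o1` gives > 100000 nM, which is a limit of the assay and not a number. Compound 2 `CC(C)(C)N(Cc1ccc([N+](=O)[O-])cc1)C(=O)COC(=O)c1ccc([N+](=O)[O-])o1` gives > 100000 nM, again a limit. Compound 1 `CC(C)(C)N(CCCc1ccccc1)C(=O)COC(=O)c1ccc([N+](=O)[O-])o1` gives "not active" (no number reported), with no number reported. Compound 3 therefore has no exact position, and the evidence amounts to the limit of > 100000 nM in this assay, at which 2 of the 3 values shown sit.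

The next structure is compound 4 `CC(=O)Oc1ccc(CN(C(=O)COC(=O)c2ccc([N+](=O)[O-])o2)C(C)(C)C)cc1`, which carries 4-acetoxyphenyl in place of 3-nitrophenyl on a saturated chain carbon bound to an amide-type nitrogen. Among the compounds with values here, the one measured step at this place exchanges 4-nitrophenyl for 3-nitrophenyl, and it is a step that the two limits leave unreadable from compound 2 to compound 3. That step has no readable size to carry over, so nothing beyond the scatter is expected in this assay, in either direction. The expected change is a number no higher from compound 3 to compound 4 (the limit leaves the size open). The assay may well report only a limit again. For compound 4 the estimate is 100000 nM, with an expected range from 40000 nM to 200000 nM.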

Compound 4, half-maximal cytotoxic concentration: > 100000 nM
Compound 4 was reported as a limit (the forecaster's own chance of this, stated with the estimate: 65%); the middle value lies on the limit itself.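

Compound 4, like compound 2 and compound 3, is reported only as a limit in this assay, and the steps among these three compounds cannot be read. The compounds shown leave open at what concentration each would harm the cells, and whether 3-nitrophenyl and 4-acetoxyphenyl differ there at all.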